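This account rests on a few compounds, and the source may have more. Where it says the series, first, only, none or still open, it means among the compounds named here.

Three members of the series are measured in an ADME assay on Vero cells (Chlorocebus sabaeus) for cytotoxicity; a lower number here means a stronger inhibitor, a higher number a weaker inhibitor. Compound 1 `COc1ccc(CN2C(=O)c3cccnc3C2=O)cc1OC` gives > 100000 nM, which is a limit of the assay and not a number. Compound 2 `O=C1c2nccnc2C(=O)N1Cc1ccccc1` gives > 100000 nM, again a limit. Compound 3 `COc1ccc(CN2C(=O)c3cccnc3C2=O)cc1` gives > 100000 nM, also a limit. The step from compound 3 to compound 1, (methoxy in place of hydrogen on an aromatic carbon), comes out as a step that the two limits leave unreadable from compound 3 to compound 1; its size cannot be read because of the limit of > 100000 nM in this assay, at which 3 of the 3 values shown sit. The cores of compound 2 and compound 3 differ, but that difference is not broken down here. Compound 4 `COc1ccc(CN2C(=O)c3nccnc3C2=O)cc1` is not yet measured; it arises from compound 2 by methoxy in place of hydrogen on an aromatic carbon. This is the same kind of change as from compound 3 to compound 1, though the surroundings differ: in compound 4 the methoxy enters para to a large group, whereas in compound 1 it enters ortho to a methoxy group and meta to a large group. Beside the unreadable earlier step, the step from compound 2 to compound 4 is expected to be a step that the limit leaves unreadable from compound 2 to compound 4, resting on the shared limit of > 100000 nM in this assay, at which 3 of the 3 values shown sit, at which compound 2 sits. Compound 4 is therefore expected at 150000 nM, between 60000 nM and 400000 nM, most likely reported again only as a limit.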

Compound 4, half-maximal inhibitory concentration: > 100000 nM
Compound 4 ended at the assay's limit (the forecaster's own chance of this, stated with the estimate: 85%); the middle value lies beyond the limit too.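

No new step can be read: compound 2 and compound 4 both stay at a limit of the assay, so the methoxy change between them has no readable size, because both values rest on the same limit: the limit of > 100000 nM in this assay, at which 4 of the 4 values shown sit.

The compounds shown leave open the size of any methoxy step in this assay and the concentration at which any of these compounds would reach half-maximal inhibition.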